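Aryl substituent swap on the cyclopentyl urea series

The source may hold more compounds than are shown below. What is called first, only, known or untested is meant among the compounds shown, and "the series" means these compounds.

Measured so far in an assay on microsomes for inhibition of acyl-CoA:cholesterol acyltransferase (Oryctolagus cuniculus); on this read-out higher numbers stand for weaker inhibition and lower numbers for stronger inhibition:
compound 1 `CC(C)c1cccc(C(C)C)c1NC(=O)NCC1(c2ccc(C(C)(C)C)cc2)CCCC1` gives 63 nM;
compound 2 `CC(C)c1cccc(C(C)C)c1NC(=O)NCC1(c2ccc([N+](=O)[O-])cc2)CCCC1` gives 131 nM;
compound 3 `CC(C)c1cccc(C(C)C)c1NC(=O)NCC1(c2ccc(C(=O)O)cc2)CCCC1` gives 3100 nM.

Compound 3 stands at the highest number of the three, and it is separated from both neighbours by margins well beyond the scatter: a 24-fold higher number from compound 2 to compound 3 (1.37 log units; beyond the scatter) and a 49-fold higher number from compound 1 to compound 3 (1.69 log units; beyond the scatter). The shared core is kept throughout; only the group on the aryl ring attached to the saturated ring carbon changes, and the step of a 2.1-fold higher number from compound 1 to compound 2 (0.32 log units; beyond the scatter) shows that the tert-butyl and nitro variants sit close together while carboxy stands apart.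

Compound 4 `Cc1ccc(C2(CNC(=O)Nc3c(C(C)C)cccc3C(C)C)CCCC2)c(C)c1` is the next member: 2,4-dimethylphenyl in place of 4-carboxyphenyl on a saturated ring carbon. Going by the values given here, the steps that bear on this change are the two that introduced carboxy, from compound 1 and from compound 2, both large and both raising the number. The new change removes carboxy again and puts in a group bearing only carbon, as compound 1 does. A large step in this assay, toward a lower number, is therefore expected, landing compound 4 near the range occupied by compound 1 and compound 2 rather than near compound 3.

For compound 4 the expected value in this assay is 100 nM, with a range of 40 nM to 300 nM. This estimate corresponds to a 31-fold lower number from compound 3 to compound 4 (1.49 log units; beyond the scatter), expected to be large.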

Compound 4, half-maximal inhibitory concentration: 50 nM
Compound 4: the middle estimate sits 2.0-fold (0.30 log units) above what was measured, within the range that was stated.
By their numbers in this assay, from the lowest: compounds 4 and 1 (each within the scatter of the next); then compound 2; then compound 3.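

In this assay, going by these compounds alone, the step of a 62-fold lower number from compound 3 to compound 4 (1.79 log units; beyond the scatter) shows that the high number of compound 3 does not persist when 4-carboxyphenyl gives way to a ring bearing only carbon substituents, so this saturated ring carbon tolerates an aryl group of a different substitution pattern from the earlier compounds. The step of a 1.3-fold lower number from compound 1 to compound 4 (0.10 log units; within the scatter) lies within the scatter, so in this assay 2,4-dimethylphenyl and 4-(tert-butyl)phenyl cannot be told apart, whereas the step of a 2.6-fold lower number from compound 2 to compound 4 (0.42 log units; beyond the scatter) lies beyond the scatter and separates 2,4-dimethylphenyl from 4-nitrophenyl, though only modestly. No measurement at hand explains these differences among the aryl groups.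

Whether both methyl groups are needed remains open, since unsubstituted phenyl, 2-methylphenyl and 4-methylphenyl do not appear among the compounds shown. Going by these compounds, it also remains open whether an amine or a methyl ester in place of the carboxylic acid on this aryl ring would give a number near that of compound 3 or near those of compound 1 and compound 4.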